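The source may hold more compounds than are shown below. What is called first, only, known or untested is meant among the compounds shown, and "the series" means these compounds.

Compound 1 `N=C(N)c1ccc(-c2ccc(-c3ccc(Cl)cc3)s2)s1`: 1860 nM
Compound 2 `N=C(N)c1ccc(-c2ccc(-c3ccc4ccccc4c3)s2)s1`: 2190 nM
Compound 3 `N=C(N)c1ccc(-c2ccc(-c3ccc(F)cc3)o2)o1`: 1220 nM

All three were run in a functional assay on PC-3 cells (Homo sapiens) for inhibition, read by sulforhodamine B assay, with a stated time of 48 h; a higher number here means a weaker inhibitor of growth, a lower number a stronger inhibitor of growth. In this assay compound 1 gives 1860 nM, the second highest of the three numbers. Its nearest neighbour is compound 2, which gives 2190 nM, a gap within the usual scatter; the furthest is compound 3, which gives 1220 nM, also within the scatter. No two of these three are separated beyond the scatter, so no order among them can be read off.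

Compound 4 `N=C(N)c1ccc(-c2ccc(-c3ccc(F)cc3)s2)s1` has not yet been measured. It differs from compound 1 in one place: fluoro in place of chloro on an aromatic carbon. The fluoro enters on an aromatic carbon of a six-membered aromatic ring of carbon only, para to a large group. Among the compounds with values here, no measured pair differs in exactly this way, so there is no measured step to lean on. Within the data shown here, the only hint is compound 3, which also carries fluoro and whose value 1220 nM lies within the scatter of compound 1. The step is therefore expected to be small, a 1.1-fold higher number from compound 1 to compound 4 (0.03 log units; within the scatter), with no direction beyond the scatter. Compound 4 is expected to give 2000 nM in this assay, within a range from 1000 nM to 4000 nM.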

Compound 4, concentration for 50% growth inhibition: 1770 nM
Compound 4: the middle estimate sits 1.1-fold (0.05 log units) above what was measured; low and high end bracket the measured number.
By their numbers in this assay, from the lowest: compounds 3, 4, 1 and 2 (each within the scatter of the next).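

Within the data shown here, with compound 4, a single change can be read for the first time: in this assay, fluoro in place of chloro on an aromatic carbon of a six-membered aromatic ring of carbon only, para to a large group, gives a 1.1-fold lower number from compound 1 to compound 4 (0.02 log units; within the scatter) and so resolves no difference between the two compounds. Among these compounds, at this position, then, exchanging one of these halogens for the other has no effect that this read-out can separate from the scatter of repeated measurements, something the earlier compounds, none of which formed such a pair, could only hint at. Nothing measured here explains why the two compounds stand so close, and no direction can be assigned to the step.

What the compounds shown leave open is whether this position responds to groups of another kind, such as an amine, a carboxylic acid, a methoxy group or a longer chain, since only chloro and fluoro can be compared here in a single place. Among the compounds shown here, also open is whether the same exchange would behave alike on a different core, as only this one pair tests it.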